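Swapping the Aryl Group on the Three-Membered Ring

The source may report more compounds than this note shows. Statements on the series, on what has been measured and on what is new or still open speak of the compounds shown alone.

Of the compounds shown here, two have been measured in a functional assay for agonist activity at G protein-coupled receptor 88 (Homo sapiens), read by HTRF and cAMP accumulation; on this read-out higher numbers stand for an effect only at larger amounts of compound and lower numbers for an effect already at smaller amounts. Compound 1 `CC[C@H](C)[C@H](N)CN(C(=O)[C@@H]1C[C@H]1c1cccc(OC)c1)c1ccc(-c2ccccc2)cc1` gives 3000 nM there, and compound 2 `CC[C@H](C)[C@H](N)CN(C(=O)[C@@H]1C[C@H]1c1ccccc1F)c1ccc(-c2ccccc2)cc1` gives 650 nM. Compound 2 thus holds the lower of the two numbers, and the step of a 4.6-fold lower number from compound 1 to compound 2 (0.66 log units; beyond the scatter) shows that the aryl group on the three-membered ring can move the read-out by a modest amount. Compound 3 `CC[C@H](C)[C@H](N)CN(C(=O)[C@@H]1C[C@H]1c1ccc(C#N)cc1)c1ccc(-c2ccccc2)cc1` differs from compound 2 by 4-cyanophenyl in place of 2-fluorophenyl on a saturated ring carbon. Going by the values given here, only the step from compound 1 to compound 2 bears on this change, and it concerned a different substituent on the same aryl group, so the direction for compound 3 is open; a modest step either way would not surprise, and no step beyond the scatter is the central expectation. Compound 3 is therefore expected to give about 1200 nM, within 350 nM to 4500 nM, which amounts to an expected step of a 1.8-fold higher number from compound 2 to compound 3 (0.27 log units; within the scatter) in this assay.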

Compound 3, half-maximal effective concentration: > 25000 nM
Compound 3: only a limit was reported; the forecaster's own chance of this, stated with the estimate: 5%; middle value at least 20-fold (1.31 log units) from the limit.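

The aryl group on the three-membered ring turns out to span a much wider range in this assay than the earlier pair suggested, with an at least 38-fold higher number from compound 2 to compound 3 (1.58 log units; beyond the scatter) and an at least 8.3-fold higher number from compound 1 to compound 3 (0.92 log units; beyond the scatter). So 4-cyanophenyl is not interchangeable with either 2-fluorophenyl or 3-methoxyphenyl at this position, and a change confined to this aryl group can take the series out of the measurable range. For compound 3 only a limit stands, not a number: the limit of > 25000 nM in this assay, at which 1 of the 3 values shown sits.

From the compounds shown here alone, whether the nitrile itself or its place on the aromatic ring sets this step stays open, as each of the three compounds carries a different substituent at a different place. Going by these compounds, how a plain phenyl group or an aryl group bearing a primary amide would read at this position also remains unknown.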